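A few compounds are considered here, and "the series" means these few. Any claim that something is new, unique, unknown or untested is made for them only; others in the source may bear on it.

Within the data shown here, in a functional assay, read by spectrophotometry, with a stated time of 15 min (a higher number here means a weaker inhibitor, a lower number a stronger inhibitor), compound 2 `Cc1nc2c3ccccc3ccc2c2nc3c(ccc4ccccc43)c(-c3ccccc3N)c12` gives 45.6 ug/mL, one of only two numbers measured so far, and compound 1 `Cc1nc2c3ccccc3ccc2c2nc3c(ccc4ccccc43)c(-c3nccnc3N)c12` at 47.8 ug/mL is indistinguishable from it within the scatter. The step of a 1.0-fold lower number from compound 1 to compound 2 (0.02 log units; within the scatter) swapped the entire attached ring and stayed within the scatter. Compound 3 `Cc1nc2c3ccccc3ccc2c2nc3c(ccc4ccccc43)c(-c3ccccc3S)c12` differs from compound 2 by sulfanyl in place of amino on an aromatic carbon. Among the measured compounds shown here, no measured step involves a sulfanyl group, so that one step is only a loose guide, and no shift beyond the scatter is expected. Compound 3 is therefore estimated at 45 ug/mL, between 20 ug/mL and 100 ug/mL. The expected step is a 1.0-fold lower number from compound 2 to compound 3 (0.01 log units; within the scatter).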

Compound 3, half-maximal inhibitory concentration: 49.6 ug/mL
Beside the measured number, compound 3's estimate is 1.1-fold (0.04 log units) below it; measured number inside the range.
By their numbers in this assay, from the lowest: compounds 2, 1 and 3 (each within the scatter of the next).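

In this assay, sulfanyl in place of amino on an aromatic carbon, ortho to a large group, gives a 1.1-fold higher number from compound 2 to compound 3 (0.04 log units; within the scatter), so this is the first change shown in the single group rather than in the whole attached ring, and it also stays within the scatter. The wider swap gives a 1.0-fold higher number from compound 1 to compound 3 (0.02 log units; within the scatter), which likewise stays within the scatter. No evidence at hand says why these numbers stay so close. Still open, going by these compounds, is whether a hydroxyl, a carboxylic acid or a longer chain on this same carbon would give a number beyond the scatter.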